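The source may report more compounds than this note shows. Statements on the series, on what has been measured and on what is new or still open speak of the compounds shown alone.

Compound 2 `CCCOCC(=O)Nc1cc2nc(C3CCCCC3)[nH]c2cc1N1CCCC1` carries a propoxymethyl group on the carbonyl carbon and a pyrrolidin-1-yl group on the aromatic carbon. In an ADME assay on Vero cells (Chlorocebus sabaeus) for cytotoxicity, read by resazurin assay, with a stated time of 3 days (on this read-out lower numbers stand for stronger inhibition and higher numbers for weaker inhibition), compound 2 gives > 100 ug/mL, which is a limit of the assay and not a number. Compound 2 thus stands at the limit of > 100 ug/mL in this assay, at which 2 of the 3 values shown sit, and nothing finer can be read for it. Compound 1 `Cc1ccc(C(=O)Nc2cc3nc(C4CCCCC4)[nH]c3cc2N2CCCC2)cc1` in this assay likewise gives > 100 ug/mL, again a limit. Compound 3 `CCCOCC(=O)Nc1cc2nc(C3CCCCC3)[nH]c2cc1N(C)C` in this assay gives < 50 ug/mL, a limit on the other side, at the limit of < 50 ug/mL in this assay, at which 1 of the 3 values shown sits. Among the compounds with values here, the step that the two limits leave unreadable from compound 1 to compound 2 is the only measured change on the carbonyl carbon, and the two limits leave its size unreadable. The step of an at least 2.0-fold lower number from compound 2 to compound 3 (0.30 log units; that floor lies within the scatter) changes the group on the aromatic carbon instead, and its floor lies within the scatter.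

Compound 4 `O=C(NCc1ccccc1)Nc1cc2nc(C3CCCCC3)[nH]c2cc1N1CCCC1` differs from compound 2 by benzylamino in place of propoxymethyl on a carbonyl carbon. Within the data shown here, the one measured step at the same position has no readable size, and the step at the aromatic carbon does not reach beyond the scatter, so no step beyond the scatter is expected in this assay from this change, in either direction. Compound 4 is therefore expected to give 100 ug/mL, within 50 ug/mL to 200 ug/mL, most likely again as a limit. The step of a number no higher from compound 2 to compound 4 (the limit leaves the size open) is expected to stay within the scatter.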

Compound 4, half-maximal inhibitory concentration: > 100 ug/mL
Compound 4: a limit, no number (the forecaster's own chance of this, stated with the estimate: 70%); the middle value lies on the limit itself.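

In this assay compound 4 gives > 100 ug/mL, a limit of the assay and not a number. Compound 1 and compound 2 sit at that same limit, so neither step to compound 4 can be read: the limit of > 100 ug/mL in this assay, at which 3 of the 4 values shown sit.

The compounds shown leave open how far benzylamino, propoxymethyl and 4-methylphenyl on the carbonyl carbon differ in this assay.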